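This account rests on a few compounds, and the source may have more. Where it says the series, first, only, none or still open, it means among the compounds named here.

Compound 1 `N#C/C(=C\c1c(F)c(F)c(F)c(F)c1F)C(=O)c1c[nH]c2ccccc12` gives in a functional assay on MIA cells (Homo sapiens) for inhibition, read by MTT assay, with a stated time of 72 h (a higher number here means a weaker inhibitor of growth, a lower number a stronger inhibitor of growth), a value of 21000 nM. Compound 2 `N#C/C(=C\c1ccco1)C(=O)NCc1ccc(Cl)c(Cl)c1` reaches only (the limit of > 50000 nM in this assay, at which 1 of the 3 values shown sits), so its result of > 50000 nM in this assay is a limit and not a number. Compound 3 `COc1ccc(CNC(=O)/C(C#N)=C/c2ccc(C)o2)cc1` gives 51000 nM in this assay, the highest of the two numbers recorded; the nearest number belongs to compound 1, whose value is lower by a margin that lies beyond the usual scatter of this measurement.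

Compound 4 `COc1ccc(CNC(=O)/C(C#N)=C/c2ccoc2)cc1` has not yet been measured. It differs from compound 3 in one place: furan-3-yl in place of 5-methylfuran-2-yl on a double-bonded chain carbon bound to a double-bonded chain carbon. The amide-linked methoxybenzyl part and the nitrile-bearing double bond are kept unchanged.

Within the data shown here, no step between two measured compounds covers this kind of exchange, so nothing measured here sets its size. Compound 4 is expected to give 55000 nM in this assay, with a range from 25000 nM to 120000 nM. The step of a 1.1-fold higher number from compound 3 to compound 4 (0.03 log units; within the scatter) is expected to stay within the scatter, with a fair chance that only a limit is reported.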

Compound 4, concentration for 50% growth inhibition: 8000 nM
For compound 4 the middle estimate is 6.9-fold (0.84 log units) above the measured one; measured number below the stated range.
By their numbers in this assay, from the lowest: compound 4; then compound 1; then compound 3.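

Exchanging 5-methylfuran-2-yl for furan-3-yl on a double-bonded chain carbon bound to a double-bonded chain carbon gives a 6.4-fold lower number from compound 3 to compound 4 (0.80 log units; beyond the scatter) in this assay and shows that growth inhibition at this position depends on the furan group. Both groups are five-membered aromatic rings with the same counts of hydrogen-bond donors and acceptors and no net charge, so these counted features do not distinguish them, although the number moves beyond the scatter. Nothing measured here gives a cause for this step.

The step removes the methyl group and changes the furan's point of attachment together, and the compounds shown do not separate these two changes. On these data alone, whether a thiophen-3-yl group in this place would keep the lower number also remains open.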